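The source may report more compounds than this note shows. Statements on the series, on what has been measured and on what is new or still open speak of the compounds shown alone.

Compound 1 `CC1=CC[C@H](C(C)(C)NC(=S)NN)CC1` is the starting point of the series. In a functional assay on 786-0 cells (Homo sapiens) for inhibition, read by sulforhodamine B assay, with a stated time of 48 h (a lower number here means a stronger inhibitor of growth, a higher number a weaker inhibitor of growth), compound 1 reaches only the assay limit, > 100000 nM. Compound 2 `CC1=CC[C@H](C(C)(C)NC(=S)N/N=C/c2ccccc2)CC1` gives 67000 nM in this assay. Compound 3 `CC1=CC[C@H](C(C)(C)NC(=S)N/N=C/c2ccc(F)cc2)CC1` again stops at the limit, > 100000 nM. Compound 3 thus stands at the limit, as does compound 1, while compound 2 alone yields a number; the step of an at least 1.4-fold higher number from compound 2 to compound 3 (0.17 log units; that floor lies within the scatter) describes this, and the limit of > 100000 nM in this assay, at which 2 of the 3 values shown sit, marks where two of the three values sit. Compound 4 `CC1=CC[C@H](C(C)(C)NC(=S)N/N=C/c2cccs2)CC1` differs from compound 3 by thiophen-2-yl in place of 4-fluorophenyl on a carbon with a double bond to nitrogen. Within the data shown here, only that one measured step bears on the change, and its floor lies within the scatter, so no shift beyond the scatter is expected from compound 3 to compound 4, an at least 1.1-fold lower number from compound 3 to compound 4 (0.04 log units; that floor lies within the scatter). Compound 4 is therefore estimated at 90000 nM, between 40000 nM and 150000 nM, with a fair chance that only a limit is reported.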

Compound 4, concentration for total growth inhibition: 26700 nM
For compound 4 the middle estimate is 3.4-fold (0.53 log units) above the measured one; measured number below the stated range.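

In this assay, the earlier step at this place stayed within the scatter, whereas thiophen-2-yl on the carbon with a double bond to nitrogen moves the number beyond it, with a 2.5-fold lower number from compound 2 to compound 4 (0.40 log units; beyond the scatter). Two further steps are floors only, an at least 3.7-fold lower number from compound 3 to compound 4 (0.57 log units; beyond the scatter) and an at least 3.7-fold lower number from compound 1 to compound 4 (0.57 log units; beyond the scatter), since each starts from a compound that rests at a limit: the limit of > 100000 nM in this assay, at which 2 of the 4 values shown sit.

As far as these compounds go, whether the change follows the sulfur atom or the five-membered ring stays open. So does how furan-2-yl, pyridin-2-yl or an amine on the phenyl ring would read here.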